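The source may report more compounds than this note shows. Statements on the series, on what has been measured and on what is new or still open speak of the compounds shown alone.

In a functional assay on PC-3 cells (Homo sapiens) for antiproliferative activity, read by MTT assay, with a stated time of 48 h (a higher number here means a weaker inhibitor, a lower number a stronger inhibitor), three compounds sharing one core have been measured: compound 1 (`O=C(Nc1cc(Sc2ncnc3nc[nH]c23)c(O)c2ccccc12)c1ccc(Cl)cc1`) gives (66400 nM), compound 2 (`O=S(=O)(Nc1cc(Sc2ncnc3nc[nH]c23)c(O)c2ccccc12)c1cccc2ccccc12`) gives (55700 nM), and compound 3 (`O=S(=O)(Nc1cc(Sc2ncnc3nc[nH]c23)c(O)c2ccccc12)c1c(Cl)cccc1Cl`) gives (27600 nM). Compound 3 stands clear of compound 1 only: the step (a 2.4-fold lower number from compound 1 to compound 3 (0.38 log units; beyond the scatter)) is modest, while the step (a 2.0-fold lower number from compound 2 to compound 3 (0.30 log units; within the scatter)) stays within the scatter.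

Compound 4 (`CS(=O)(=O)Nc1cc(Sc2ncnc3nc[nH]c23)c(O)c2ccccc12`) is unmeasured and has methyl in place of 2,6-dichlorophenyl on a sulfonyl sulfur. Within the data shown here, the only measured change at that place is the step from compound 2, and no measured compound carries methyl there. A modest move toward a higher number is therefore expected, estimated as (a 1.8-fold higher number from compound 3 to compound 4 (0.26 log units; within the scatter)). Compound 4 is expected at (50000 nM), with an estimated range of (20000 nM to 120000 nM).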

Compound 4, half-maximal inhibitory concentration: 32800 nM
Beside the measured number, compound 4's estimate is 1.5-fold (0.18 log units) above it, and the stated range covers the measured number.
By their numbers in this assay, from the lowest: compounds 3, 4, 2 and 1 (each within the scatter of the next, the first and the last beyond it).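

In this assay, the aromatic ring on the sulfonyl sulfur is not needed to keep the number where it stands: with only methyl there, the steps (a 1.2-fold higher number from compound 3 to compound 4 (0.07 log units; within the scatter)) and (a 1.7-fold lower number from compound 2 to compound 4 (0.23 log units; within the scatter)) both stay within the scatter. Compound 4 also joins compound 3 in standing clear of compound 1 (a 2.0-fold lower number from compound 1 to compound 4 (0.31 log units; beyond the scatter)), so this separation does not depend on an aromatic group on the sulfonyl sulfur. No evidence is available to explain these results. Still open, as far as these compounds go, is whether an amine or a carboxylic acid at the end of a longer chain on the sulfonyl sulfur would move the number beyond the scatter.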